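This account rests on a few compounds, and the source may have more. Where it says the series, first, only, none or still open, it means among the compounds named here.

- Compound 1 `O=C(CC(CC(=O)NC1Cc2ccccc2C1)c1ccc(Cl)cc1)NCCN1CCCCC1`: 86200 nM
- Compound 2 `CCN(C(=O)CC(CC(=O)NCCN1CCCCC1)c1ccc(Cl)cc1)C1Cc2ccccc2C1`: 20400 nM

In a functional assay on HeLa cells (Homo sapiens) for inhibition (a lower number here means a stronger inhibitor, a higher number a weaker inhibitor), compound 2 has the lower of the two numbers, so it is the stronger inhibitor so far. Compound 3 `CCNCCNC(=O)CC(CC(=O)N(CC)C1Cc2ccccc2C1)c1ccc(Cl)cc1` carries ethylamino in place of piperidin-1-yl on a saturated chain carbon, two bonds along the chain from an amide-type nitrogen. Among the measured compounds shown here, no measured step touches that group. For the measured compounds named here, the only guide is a modest step at an amide-type nitrogen, a 4.2-fold lower number from compound 1 to compound 2 (0.63 log units; beyond the scatter), so only a modest change is expected here, estimated as a 1.5-fold higher number from compound 2 to compound 3 (0.17 log units; within the scatter), though the direction is uncertain. For compound 3 the expected value is 30000 nM, with an estimated range from 11000 nM to 80000 nM.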

Compound 3, half-maximal inhibitory concentration: 40500 nM
For compound 3 the middle estimate is 1.4-fold (0.13 log units) below the measured one; low and high end bracket the measured number.
By their numbers in this assay, from the lowest: compounds 2 and 3 (each within the scatter of the next); then compound 1.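

In this assay, ethylamino in place of piperidin-1-yl gives a 2.0-fold higher number from compound 2 to compound 3 (0.30 log units; within the scatter). At this position, then, the six-membered non-aromatic ring can go, and a hydrogen-bond donor can come in, with no change that stands clear of the scatter. Nothing available here bears on why this is so. The compounds shown leave open whether a primary amine, a dimethylamino group or a morpholine ring in the same place would also fit this picture. They also leave open whether a longer chain before the amine would do so.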